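This account rests on a few compounds, and the source may have more. Where it says the series, first, only, none or still open, it means among the compounds named here.

Measured compounds:
compound 1 `Cc1cccc(C)c1-c1cccc(COc2ccc(CCC(=O)O)cn2)c1`: 3.5 nM
compound 2 `Cc1cccc(C)c1-c1cccc(COc2ccc(CC(C)C(=O)O)cn2)c1`: 65 nM

In a functional assay on CHO cells for agonist activity at Free fatty acid receptor 1 (Homo sapiens), read by calcium flux (a higher number here means that more compound is needed for the effect, a lower number that less compound is needed), compound 2 gives the higher of the two numbers; compound 1 gives 3.5 nM, and the step of a 19-fold higher number from compound 1 to compound 2 (1.27 log units; beyond the scatter) came from the methyl added there. Compound 3 `COC(Cc1ccc(OCc2cccc(-c3c(C)cccc3C)c2)nc1)C(=O)O` differs from compound 2 by methoxy in place of methyl on a saturated chain carbon bound to a carbonyl carbon and a saturated chain carbon. For the measured compounds named here, only that one earlier step bears on this change, and it measures a different group at the same carbon, so it gives no direct guide. A small move back toward compound 1 is expected, a 2.2-fold lower number from compound 2 to compound 3 (0.34 log units; beyond the scatter), with compound 3 estimated at 30 nM, between 8 nM and 120 nM.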

Compound 3, half-maximal effective concentration: 120 nM
For compound 3 the middle estimate is 4.0-fold (0.60 log units) below the measured one; the measured number falls inside the stated range.
By their numbers in this assay, from the lowest: compound 1; then compounds 2 and 3 (each within the scatter of the next).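

In this assay, methoxy in place of methyl on this saturated chain carbon gives a 1.8-fold higher number from compound 2 to compound 3 (0.27 log units; within the scatter), so the two groups cannot be told apart here. Methoxy in place of hydrogen at the same carbon gives a 34-fold higher number from compound 1 to compound 3 (1.54 log units; beyond the scatter), so the large loss is not confined to methyl and also appears with a group that brings in an oxygen. Nothing measured here explains this loss. On these data alone, whether a fluorine or a hydroxyl on this carbon would stay as close to the hydrogen of the unbranched chain remains open, and so does the effect of a longer chain such as ethyl.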